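Swapping an aromatic ring on the thiazole of compound 3

This account rests on a few compounds, and the source may have more. Where it says the series, first, only, none or still open, it means among the compounds named here.

Measured so far:
- compound 1, `O=C(O)CC1COc2cc(OCc3nc(-c4ccccc4)cs3)ccc21`, 0.16%
- compound 2, `Cc1nc(-c2cccs2)sc1COc1ccc2c(c1)OCC2CC(=O)O`, 35.2%
- compound 3, `Cc1nc(-c2ccsc2)sc1COc1ccc2c(c1)OCC2CC(=O)O`, 56.5%

In a functional assay on CHO cells for agonist activity at Free fatty acid receptor 1 (Homo sapiens), read by FLIPR and calcium flux, tested at 100 nM (on this read-out lower numbers stand for a weaker effect and higher numbers for a stronger effect at the one concentration tested), compound 3 stands highest of the three, with compound 2 next and compound 1 far below. Among the compounds with values here, the one measured step is a number 21.3 percentage points higher from compound 2 to compound 3 (beyond the scatter). Compound 4, `Cc1ccccc1-c1nc(C)c(COc2ccc3c(c2)OCC3CC(=O)O)s1`, differs from compound 3 as follows: 2-methylphenyl in place of thiophen-3-yl on an aromatic carbon. Within the data shown here, no measured step covers this change; compound 1, which carries a plain phenyl on a similar core, gives 0.16%, although it differs from compound 3 in more than one place. Among the measured compounds shown here, a decrease is therefore expected, likely larger than the one seen from compound 2 to compound 3, with wide uncertainty. For compound 4 the estimate in this assay is 25%, ranging from 2% to 60%, a step of a number 31.5 percentage points lower from compound 3 to compound 4 (beyond the scatter).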

Compound 4, a percentage reported as activity, at one concentration (the size of the read-out at that concentration, not a potency): 10.7%
Compound 4: middle estimate off by 14.3 percentage points, on the high side; measured number inside the range.
By their numbers in this assay, from the lowest: compound 1; then compound 4; then compound 2; then compound 3.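

In this assay, this position on the shared core now carries a six-membered aromatic ring of carbon only, and 2-methylphenyl reads below both thiophene compounds, with a number 45.8 percentage points lower from compound 3 to compound 4 (beyond the scatter) and a number 24.5 percentage points lower from compound 2 to compound 4 (beyond the scatter) on the same core. The position is therefore sensitive to which aromatic ring it carries, not only to how a thiophene is attached. Nothing measured here explains this drop. Whether the methyl group or the six-membered ring itself accounts for it remains open. So does the effect of plain phenyl on this core, or of a ring bearing an amine.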